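Estimating a New Aryl Group on a Shared Core

A few compounds are considered here, and "the series" means these few. Any claim that something is new, unique, unknown or untested is made for them only; others in the source may bear on it.

- compound 1 `Cc1nc(-c2ccccc2F)c(C(=O)N2CCN(c3cc(Cl)ccc3C)CC2)o1`: 229 nM
- compound 2 `Cc1ccc(C)c(N2CCN(C(=O)c3oc(C)nc3-c3ccccc3F)CC2)c1`: 319 nM

In a functional assay on HL-60 cells (Homo sapiens) for inhibition, read by MTT assay, with a stated time of 72 h (a higher number here means a weaker inhibitor, a lower number a stronger inhibitor), compound 2 gives 319 nM, which lies within the usual scatter of compound 1 at 229 nM, so the two cannot be told apart.

Compound 3 `C=C(C)c1cccc(N2CCN(C(=O)c3oc(C)nc3-c3ccccc3F)CC2)c1` keeps the shared core but changes the aromatic group: 3-(1-methylethenyl)phenyl in place of 2,5-dimethylphenyl on an amine nitrogen in a ring. In words, 3-(1-methylethenyl)phenyl stands in place of 2,5-dimethylphenyl on an amine nitrogen in a ring.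

Within the data shown here, only one measured step bears on this: a 1.4-fold higher number from compound 1 to compound 2 (0.14 log units; within the scatter), with methyl in place of chloro on an aromatic carbon. Among the measured compounds shown here, that step altered a single substituent, whereas this change replaces the whole group, and no measured compound carries the new group. The direction therefore remains uncertain, but a modest move toward a higher number, meaning a weaker inhibitor, is expected in this assay.

The expected change is a 1.3-fold higher number from compound 2 to compound 3 (0.10 log units; within the scatter).

For compound 3 the estimate is 400 nM, with an expected range of 130 nM to 1200 nM.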

Compound 3, half-maximal inhibitory concentration: "not active" (no number reported)
Compound 3 has no reported number here; no gap can be computed for the estimate.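

In this assay, among these compounds, compound 3 is reported as not active, with no number, so no step from compound 2 to compound 3 can be read. Nothing shown here accounts for this result. The compounds shown leave open how large the effect of 3-(1-methylethenyl)phenyl in place of 2,5-dimethylphenyl is.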